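Cyanophenyl analogue in the aryl-substituted tetrahydroquinoline series

The compounds below may be only part of what the source reports. "The series", "measured", "known", "first", "only" and "open" are said of these compounds alone.

Of the compounds shown here, two have been measured. Among the measured compounds shown here, compound 1 `COc1ccc(S(=O)(=O)N2CCc3cccc(-c4ccc([N+](=O)[O-])cc4)c32)cc1` gives 52.5 nM in a functional assay on KB cells (Homo sapiens) for inhibition, with a stated time of 72 h (on this read-out lower numbers stand for stronger inhibition and higher numbers for weaker inhibition), and compound 2 `COc1ccc(S(=O)(=O)N2CCc3cccc(-c4ccncc4)c32)cc1` gives 96 nM in this assay; the only measured step, a 1.8-fold higher number from compound 1 to compound 2 (0.26 log units; within the scatter), leaves both compounds within the scatter of each other, so compound 2 stands level with compound 1 on the numbers so far.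

Compound 3 `COc1ccc(S(=O)(=O)N2CCc3cccc(-c4ccc(C#N)cc4)c32)cc1` is the next change: 4-cyanophenyl in place of pyridin-4-yl on an aromatic carbon. For the measured compounds named here, the one step that bears on it, a 1.8-fold higher number from compound 1 to compound 2 (0.26 log units; within the scatter), was small, so for compound 3 no step beyond the scatter is expected, and the estimate is a 1.6-fold lower number from compound 2 to compound 3 (0.20 log units; within the scatter). Compound 3 is estimated at 60 nM, with a range from 25 nM to 150 nM.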

Compound 3, half-maximal inhibitory concentration: 31.1 nM
Beside the measured number, compound 3's estimate is 1.9-fold (0.29 log units) above it; measured number inside the range.
By their numbers in this assay, from the lowest: compounds 3, 1 and 2 (each within the scatter of the next, the first and the last beyond it).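

Among the compounds shown here, at this place on the core, a 3.1-fold lower number from compound 2 to compound 3 (0.49 log units; beyond the scatter) in this assay is the first step beyond the scatter, with 4-cyanophenyl in place of pyridin-4-yl. The nitro compound does not follow this separation from pyridin-4-yl, and a 1.7-fold lower number from compound 1 to compound 3 (0.23 log units; within the scatter) leaves cyano and nitro unresolved, so no ranking of the two phenyl substituents can be drawn. No measurement available here accounts for the step. Still open, as far as these compounds go, is whether a phenyl ring bearing an amine, a carboxylic acid or a methoxy group at the same place stays in this range. Unsubstituted phenyl and pyridin-3-yl also remain open, so the pyridin-4-yl result cannot yet be set against either.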